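Nitrophenyl Isomer Swap on a Chalcone Pyrazole Series

The source may hold more compounds than are shown below. What is called first, only, known or untested is meant among the compounds shown, and "the series" means these compounds.

Compound 1 `CC1(C)Cc2c(ccc(C(=O)/C=C/c3cn(-c4ccccc4)nc3-c3ccccc3)c2OCc2ccccc2)O1`: in a functional assay on PC-3 cells (Homo sapiens) for antiproliferative activity, read by MTT assay, with a stated time of 48 h (on this read-out lower numbers stand for stronger inhibition and higher numbers for weaker inhibition), compound 1 gives > 100000 nM, which is a limit of the assay and not a number.
Compound 2 `CC1(C)Cc2c(OCc3ccccc3)ccc(C(=O)/C=C/c3cn(-c4ccccc4)nc3-c3ccc([N+](=O)[O-])cc3)c2O1`: in this assay compound 2 gives > 100000 nM, likewise a limit.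
Compound 3 `CC1(C)Cc2c(ccc(C(=O)/C=C/c3ccccc3)c2OCc2ccccc2)O1`: in this assay compound 3 gives > 100000 nM, likewise a limit.

Compound 2 therefore stands where every measured compound stands, at the limit (the limit of > 100000 nM in this assay, at which 3 of the 3 values shown sit). Within the data shown here, no step between measured compounds can be computed, since none of the three has a numerical value. Compound 4 `CC1(C)Cc2c(OCc3ccccc3)ccc(C(=O)/C=C/c3cn(-c4ccccc4)nc3-c3cccc([N+](=O)[O-])c3)c2O1` differs from compound 2 by 3-nitrophenyl in place of 4-nitrophenyl on an aromatic carbon. Nothing measured here separates any nitrophenyl from any other group, so the expected step of a number no higher from compound 2 to compound 4 (the limit leaves the size open) is none beyond the scatter. Compound 4 is accordingly expected at 100000 nM, within 30000 nM to 300000 nM, most likely reported again only as a limit.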

Compound 4, half-maximal inhibitory concentration: 5900 nM
For compound 4 the middle estimate is 17-fold (1.23 log units) above the measured one; the whole stated range lies above it.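

In this assay, 3-nitrophenyl in place of 4-nitrophenyl on the five-membered aromatic ring with 2 nitrogen gives an at least 16-fold lower number from compound 2 to compound 4 (1.22 log units; beyond the scatter). Among these compounds, this shows that activity at this position depends on where the nitro group stands on the phenyl ring, which the earlier compounds could not show. Compound 2 sits at a limit, so the step sets a bound and not a size: the limit of > 100000 nM in this assay, at which 3 of the 4 values shown sit.

As far as these compounds go, whether a 3-aminophenyl or 3-methoxyphenyl at this position would match compound 4 stays open. So does whether the carboxylic acid counterpart, 3-carboxyphenyl, would.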